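The compounds below may be only part of what the source reports. "The series", "measured", "known", "first", "only" and "open" are said of these compounds alone.

Compound 1 `CC(C)(C)OC(=O)N1CCN(c2c(C(=O)NCc3ccc(F)cc3)nc(Br)c3cccnc23)CC1`: > 10000 nM, a limit
Compound 2 `CN(C)CCCNc1c(C(=O)NCc2ccc(F)cc2)nc(Br)c2cccnc12`: 8000 nM

Going by the values given here, the series so far has been measured in a functional assay on LNCaP cells (Homo sapiens) for cytotoxicity, read by MTT assay, with a stated time of 72 h; on this read-out lower numbers stand for stronger inhibition and higher numbers for weaker inhibition. Among the compounds with values here, compound 2 gives 8000 nM, the only actual number available. Compound 1 gives > 10000 nM, which is a limit of this assay and not a number. Within the data shown here, compound 2 therefore has no measured neighbour against which its position can be ranked, and no step between measured compounds is available.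

The next compound, compound 3 `O=C(NCc1ccc(F)cc1)c1nc(Br)c2cccnc2c1N1CCNCC1`, has not yet been measured. It carries piperazin-1-yl in place of (3-(dimethylamino)propyl)amino on an aromatic carbon. The site is para to the bromo group and two atoms from the ring nitrogen.

Among the measured compounds shown here, with no measured step to draw on, the expectation rests on compound 2 at 8000 nM as the single anchor. No change beyond the scatter of this assay is expected in either direction. The estimated change is a 1.1-fold lower number from compound 2 to compound 3 (0.06 log units; within the scatter). A result reported only as a limit would not be surprising. For compound 3 the expected value is 7000 nM, with an estimated range of 2500 nM to 16000 nM.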

Compound 3, half-maximal inhibitory concentration: 4500 nM
Compound 3: middle estimate off by 1.6-fold (0.19 log units), on the high side; the range from low to high includes it.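

In this assay, piperazin-1-yl in place of (3-(dimethylamino)propyl)amino, on the aromatic carbon para to a bromo group and two atoms from the ring nitrogen, gives a 1.8-fold lower number from compound 2 to compound 3 (0.25 log units; within the scatter), so this read-out does not separate the ring from the open chain at this position. Hydrogen in place of tert-butoxycarbonyl on the ring amine nitrogen gives an at least 2.2-fold lower number from compound 1 to compound 3 (0.34 log units; beyond the scatter), the only step in the series so far that is printed as beyond the scatter, and this change lies on the piperazine nitrogen rather than at the point of attachment to the core. The size of that step is only a bound, since the value for compound 1 is a limit of the assay and not a number: the limit of > 10000 nM in this assay, at which 1 of the 3 values shown sits.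

Going by these compounds, whether a small group such as methyl or acetyl on the free piperazine nitrogen behaves like hydrogen or like tert-butoxycarbonyl remains open. Also open, on these data alone, is whether a morpholine ring or a shorter aminoalkyl chain at the same aromatic carbon would move the number beyond the scatter.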